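This account rests on a few compounds, and the source may have more. Where it says the series, first, only, none or still open, it means among the compounds named here.

Measured so far in an assay on HEK293 cells for positive allosteric modulation of metabotropic glutamate receptor 2 (Rattus norvegicus), read by thallium flux, with a stated time of 2.5 min; a lower number here means a smaller maximal response, a higher number a larger maximal response:
compound 1 `Cc1c(OCCCCOc2ccc(F)c(C(=O)O)c2)ccc(C(=O)CC2CCCC2)c1O`: 81%
compound 2 `CCCC(=O)c1ccc(OCCCCOc2ccc(F)c(C(=O)O)c2)c(C)c1O`: 87.5%

Compound 1 and compound 2 sit within the scatter of each other: a number 6.5 percentage points higher from compound 1 to compound 2 (within the scatter). Compound 3 `Cc1c(OCCCCOc2ccc(F)c(C(=O)O)c2)ccc(C(=O)CC2CCCC2)c1C` is not yet measured; it differs from compound 1 by methyl in place of hydroxy on an aromatic carbon. For the measured compounds named here, the one measured step, ethyl in place of cyclopentyl on a saturated chain carbon bound to a carbonyl carbon, touches a different site and says nothing about an exchange on the aromatic ring. Going by the values given here, no measured step bears on this change, so the size of the step in this assay is open; the step expected is a number 6 percentage points lower from compound 1 to compound 3 (within the scatter), with a wide range. Compound 3 is estimated at 75%, range 45% to 100%.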

Compound 3, largest response reached (reported as percent of maximum), in percent of the reference or control that the assay uses: 14.6%
Compound 3: the middle estimate sits 60.4 percentage points above what was measured, and the stated range ends above it.
By their numbers in this assay, from the lowest: compound 3; then compounds 1 and 2 (each within the scatter of the next).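

On this aromatic carbon, ortho to a (cyclopentylmethyl)carbonyl group and ortho to a methyl group, methyl is a poor replacement for hydroxy in this assay: the exchange gives a number 66.4 percentage points lower from compound 1 to compound 3 (beyond the scatter). For the compounds shown here, the chain exchange, by contrast, gave a number 6.5 percentage points higher from compound 1 to compound 2 (within the scatter), so this aromatic carbon is the first place where a single change moves the maximal response beyond the scatter. Nothing available accounts for the size of this drop. Still open, as far as these compounds go, are how a methoxy, an amine or a fluorine on this carbon would read, and whether the hydroxy-to-methyl exchange costs as much with the ethyl of compound 2 in place of cyclopentyl.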